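This account rests on a few compounds, and the source may have more. Where it says the series, first, only, none or still open, it means among the compounds named here.

Compound 1 `CC(=O)Cn1nnc(Cc2ccc(-c3ccccc3)cc2)n1`: in a functional assay on HEK293 cells for agonist activity at transient receptor potential cation channel subfamily V member 1 (Homo sapiens), read by calcium flux (a higher number here means that more compound is needed for the effect, a lower number that less compound is needed), compound 1 gives only the limit > 100000 nM.
Compound 2 `CC(=O)Cn1nnc(CNC(=O)c2ccc(-c3ccccc3)cc2)n1`: in this assay compound 2 gives only the limit > 100000 nM.

Compound 2 stands where every value shown stands: at the limit of > 100000 nM in this assay, at which 2 of the 2 values shown sit, so no number is known for it, only that the assay reached its limit. Compound 3 `COC(=O)Cn1nnc(CNC(=O)c2ccc(-c3ccccc3)cc2)n1` differs from compound 2 by methoxy in place of methyl on a carbonyl carbon. Among the measured compounds shown here, no step between measured compounds is known, and nothing in the two values shown points in either direction; both sit at the limit. The step from compound 2 to compound 3 is therefore expected to amount to a number no higher from compound 2 to compound 3 (the limit leaves the size open), none beyond the scatter. In this assay compound 3 is estimated to give 100000 nM, with a range from 30000 nM to 300000 nM, and it is expected that the assay will most likely again report only a limit for compound 3.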

Compound 3, half-maximal effective concentration: > 100000 nM
Compound 3 ended at the assay's limit (the forecaster's own chance of this, stated with the estimate: 85%); the middle value lies on the limit itself.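

No step can be read from compound 2 to compound 3, methoxy in place of methyl on a carbonyl carbon, because neither compound gives a number: the limit of > 100000 nM in this assay, at which 3 of the 3 values shown sit. The compounds shown leave open whether any of them would reach a measurable effect in this assay at all.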